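The source may hold more compounds than are shown below. What is called first, only, known or untested is meant among the compounds shown, and "the series" means these compounds.

Measured so far in an ADME assay on THP-1 cells (Homo sapiens) for cytotoxicity; on this read-out higher numbers stand for lower toxicity in this test and lower numbers for higher toxicity in this test:
compound 1 `COc1ccc(-n2cc(COc3ccc(/C=N/Nc4nc(-c5ccc([N+](=O)[O-])cc5)cs4)cc3)nn2)cc1` — 37900 nM
compound 2 `COc1ccc(-c2csc(N/N=C/c3ccc(OCc4cn(-c5ccc(OC)cc5)nn4)cc3)n2)cc1` — 39000 nM
compound 3 `COc1ccc(-n2cc(COc3ccc(/C=N/Nc4nc(-c5cc6cc(Br)cc(OC)c6oc5=O)cs4)cc3)nn2)cc1` — 30300 nM

Compound 2 gives the highest of the three numbers, yet its nearest neighbour compound 1 and its furthest neighbour compound 3 both sit within the scatter of it, so the three compounds cannot be told apart in this assay. For the measured compounds named here, the single measured step, a 1.0-fold higher number from compound 1 to compound 2 (0.01 log units; within the scatter), was itself within the scatter.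

Compound 4 `COc1ccc(-n2cc(COc3ccc(/C=N/Nc4nc(-c5ccc(-c6ccccc6)cc5)cs4)cc3)nn2)cc1` is the next compound, differing from compound 2 by phenyl in place of methoxy on an aromatic carbon. Going by the values given here, no measured step bears on a methoxy-to-phenyl change here; the only comparison available, the nitro-to-methoxy step, changed nothing beyond the scatter. A step of no more than the scatter is therefore expected, a 1.2-fold lower number from compound 2 to compound 4 (0.07 log units; within the scatter), in either direction. Compound 4 is estimated at 33000 nM, with a range of 12000 nM to 80000 nM.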

Compound 4, half-maximal cytotoxic concentration: 35800 nM
Compound 4: the middle estimate sits 1.1-fold (0.04 log units) below what was measured, and the stated range covers the measured number.
By their numbers in this assay, from the lowest: compounds 3, 4, 1 and 2 (each within the scatter of the next).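

At this position, on an aromatic carbon para to a large group, adding a whole aromatic ring does not shift the read-out in this assay: phenyl in place of methoxy gives a 1.1-fold lower number from compound 2 to compound 4 (0.04 log units; within the scatter), and phenyl in place of nitro gives a 1.1-fold lower number from compound 1 to compound 4 (0.02 log units; within the scatter). Methoxy, nitro and phenyl therefore cannot be told apart here, despite the difference in size between them. Nothing available accounts for this flat result.

From the compounds shown here alone, whether an amine or a carboxylic acid at this position would move the number beyond the scatter remains open. So does whether any change elsewhere on the shared core would do so.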